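Working notes: one stereocentre changed in compound 1

The source may hold more compounds than are shown below. What is called first, only, known or untested is meant among the compounds shown, and "the series" means these compounds.

Compound 1 `O=C(N[C@@H]1CCCC[C@H]1O)c1cnc(OCC2CC2)c(-c2ccc(Cl)cc2)c1` gives 0.064 mL/min/kg
Compound 2 `COCCOc1ncc(C(=O)N[C@@H]2CCCC[C@H]2O)cc1-c1ccc(Cl)cc1` gives 0.098 mL/min/kg
Compound 3 `O=C(N[C@@H]1CCCC[C@H]1O)c1cnc(OCc2ccccc2)c(-c2ccc(Cl)cc2)c1` gives 0.02 mL/min/kg

In an ADME assay (liver) for pharmacokinetics, with Liver microsome (Rattus norvegicus) as the target, read by LC-MS, using microsomes, tested at 2 uM (a lower number here means slower removal, a higher number faster removal of the compound), compound 1 at 0.064 mL/min/kg belongs to the upper pair of the three numbers, while compound 3 stands alone at the low end. The measured steps are a 1.5-fold higher number from compound 1 to compound 2 (0.19 log units; within the scatter), a 3.2-fold lower number from compound 1 to compound 3 (0.51 log units; beyond the scatter) and a 4.9-fold lower number from compound 2 to compound 3 (0.69 log units; beyond the scatter). All three replace the group on a saturated chain carbon bound to an oxygen on an aromatic ring.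

The next compound is compound 4 `O=C(N[C@@H]1CCCC[C@@H]1O)c1cnc(OCC2CC2)c(-c2ccc(Cl)cc2)c1`, and its change from compound 1 is the two compounds have the same atoms and bonds and differ only in configuration as drawn: 1 of 2 stereo elements differ; a stereocentre at a saturated ring carbon is drawn R in compound 1 and S in compound 4. A stereocentre at a saturated ring carbon is drawn R in compound 1 and S in compound 4. Going by the values given here, none of the measured steps alters a stereocentre, so the data hold no direct measure of this change and give no direction for it. They show only what swapping the chain group has done, at most a 4.9-fold lower number from compound 2 to compound 3 (0.69 log units; beyond the scatter), and that range is a loose guide to the width of the estimate. No step beyond the scatter is expected in this assay, and the expected step is a 1.1-fold higher number from compound 1 to compound 4 (0.04 log units; within the scatter) with its direction left open. The estimate for compound 4 is 0.07 mL/min/kg, with an expected range from 0.025 mL/min/kg to 0.2 mL/min/kg.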

Compound 4, clearance: 0.163 mL/min/kg
Estimate against measurement, compound 4: 2.3-fold (0.37 log units) below; the measured number falls inside the stated range.
By their numbers in this assay, from the lowest: compound 3; then compounds 1, 2 and 4 (each within the scatter of the next, the first and the last beyond it).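

In this assay, a 2.5-fold higher number from compound 1 to compound 4 (0.41 log units; beyond the scatter), so the drawn configuration at a saturated ring carbon moves the number beyond the scatter with no atom or bond altered. Going by these compounds alone, the earlier steps all replaced the group on the saturated chain carbon bound to an oxygen on an aromatic ring, so this is the first sign that a second site, and a purely stereochemical change, also registers in this read-out, with the S form giving the higher number in this single pair. The step is assigned to this stereocentre alone because of the following: the fact that compounds 1 and 4 differ only in the configuration as drawn

As far as these compounds go, it remains open whether the same change from R to S gives a step of similar size and direction with methoxymethyl or phenyl in place of cyclopropyl, and what a change at the other stereocentre would do. Also open, from the compounds shown here alone, is how an amine in place of the hydroxyl on the saturated ring would read in this assay.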